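Adding a second chloro to the fused core of compound 1

The source may report more compounds than this note shows. Statements on the series, on what has been measured and on what is new or still open speak of the compounds shown alone.

Measured compounds:
Compound 1 `ClCc1ccc(Cn2cnc3c(Cl)ncnc32)cc1`: 6760 nM
Compound 2 `ClCc1cccc(Cn2cnc3c(Cl)ncnc32)c1`: 5120 nM
Compound 3 `ClCc1ccc(Cn2cnc3nc(Cl)nc(Cl)c32)cc1`: 3890 nM

In a functional assay on HOP-62 cells (Homo sapiens) for cytotoxicity, read by sulforhodamine B assay, with a stated time of 48 h (on this read-out higher numbers stand for weaker inhibition of growth and lower numbers for stronger inhibition of growth), compound 1 gives 6760 nM, the top number of the three, yet compound 2 and compound 3 both lie within the usual scatter of it, so the three compounds are not told apart by this read-out. Compound 4 `ClCc1ccc(Cn2cnc3c(Cl)nc(Cl)nc32)cc1` differs from compound 1 by chloro in place of hydrogen on an aromatic carbon. Going by the values given here, no direct step between measured compounds is known for this change. Compound 3 also carries two chloro groups on its core and gives 3890 nM, a number within the scatter of compound 1. Compound 4 is therefore expected to give 5000 nM, between 2500 nM and 10000 nM, with a 1.4-fold lower number from compound 1 to compound 4 (0.13 log units; within the scatter) estimated as a step not beyond the scatter.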

Compound 4, concentration for total growth inhibition: 5130 nM
Estimate against measurement, compound 4: 1.0-fold (0.01 log units) below, within the range that was stated.
By their numbers in this assay, from the lowest: compounds 3, 2, 4 and 1 (each within the scatter of the next).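

In this assay, putting chloro in place of hydrogen on the aromatic carbon between two ring nitrogen atoms gives a 1.3-fold lower number from compound 1 to compound 4 (0.12 log units; within the scatter) and so stays within the scatter. Going by these compounds alone, this is the first direct step at this position, and on this read-out chloro there cannot be told apart from hydrogen. No independent evidence bears on this result. On these data alone, whether an amine or a methoxy group on this same carbon would give a step beyond the scatter remains open.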